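A few compounds are considered here, and "the series" means these few. Any claim that something is new, unique, unknown or untested is made for them only; others in the source may bear on it.

So far two compounds have been measured, compound 1 (`CCS(=O)(=O)n1cc2c(n1)CN([C@H]1CO[C@H](c3cc(F)ccc3F)[C@@H](N)C1)C2`) and compound 2 (`CCC(=O)Nc1n[nH]c2c1CN([C@H]1CO[C@H](c3cc(F)ccc3F)[C@@H](N)C1)C2`). In an ADME assay on the whole organism (plasma) for pharmacokinetics, with Rattus norvegicus as the target (on this read-out lower numbers stand for slow clearance and higher numbers for fast clearance), compound 1 gives 1.6 mL/min/kg and compound 2 gives 60 mL/min/kg as the higher of the two numbers, a gap well beyond the scatter. Compound 3 (`N[C@H]1C[C@@H](N2Cc3[nH]nc(NC(=O)C4CC4)c3C2)CO[C@@H]1c1cc(F)ccc1F`) departs from compound 2 at one place, with cyclopropyl in place of ethyl on a carbonyl carbon. Among the measured compounds shown here, no measured pair isolates this change, so the expectation rests on compound 2 alone (60 mL/min/kg). In this assay the expected change is small and slightly downward, with no step beyond the scatter (a 1.3-fold lower number from compound 2 to compound 3 (0.12 log units; within the scatter)). In this assay compound 3 is estimated at 45 mL/min/kg with an expected range (18 mL/min/kg to 90 mL/min/kg).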

Compound 3, clearance: 64 mL/min/kg
Estimate against measurement, compound 3: 1.4-fold (0.15 log units) below; the range from low to high includes it.
By their numbers in this assay, from the lowest: compound 1; then compounds 2 and 3 (each within the scatter of the next).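

In this assay, putting cyclopropyl in place of ethyl on a carbonyl carbon gives a 1.1-fold higher number from compound 2 to compound 3 (0.03 log units; within the scatter). Among the compounds shown here, this is the first pair to isolate a single change at this place, and it shows that the read-out does not separate these two carbon groups, even though cyclopropyl brings one more carbon and a three-membered ring. The compounds shown offer no measurement that would explain this result.

From the compounds shown here alone, whether this place tolerates everything equally stays open, since only these two small carbon groups have been compared there, and a longer chain, a phenyl ring or an amine on the same carbonyl carbon could behave differently. Compound 2 and compound 3 differ from compound 1 in more than one place, so no single change accounts for the value of compound 1, 1.6 mL/min/kg.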